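The source may hold more compounds than are shown below. What is called first, only, known or untested is meant among the compounds shown, and "the series" means these compounds.

Measured compounds in an in vitro functional assay on cells for agonist activity at Bombesin receptor subtype-3 (Mus musculus), read by luminescence and calcium flux; a higher number here means that more compound is needed for the effect, a lower number that less compound is needed:

Compound 1 `COc1cccc(Cc2cnc(CCc3ccc(-c4ccccc4C(=O)O)cc3)[nH]2)c1`, which in this assay gives 79 nM
Compound 2 `Cc1cccc(Cc2cnc(CCc3ccc(-c4ccccc4C(=O)O)cc3)[nH]2)c1`, which in this assay gives 75 nM
Compound 3 `CC(C)(C)CCc1cnc(CCc2ccc(-c3ccccc3C(=O)O)cc2)[nH]1`, which in this assay gives 6.2 nM

Compound 3 stands lowest of the three, with a 12-fold lower number from compound 2 to compound 3 (1.08 log units; beyond the scatter) and a 13-fold lower number from compound 1 to compound 3 (1.11 log units; beyond the scatter) both beyond the scatter, while a 1.1-fold lower number from compound 1 to compound 2 (0.02 log units; within the scatter) lies within it. Compound 4 `O=C(O)c1ccccc1-c1ccc(CCc2ncc(CC3CCCCCC3)[nH]2)cc1` differs from compound 3 by cycloheptyl in place of neopentyl on a saturated chain carbon bound to an aromatic carbon. For the measured compounds named here, no measured step exchanges one saturated group for another; the two large steps replace an aryl group with neopentyl, and the step between the two aryl groups is within the scatter. A change in this assay for compound 4 is therefore expected to stay within the scatter, a 1.2-fold lower number from compound 3 to compound 4 (0.09 log units; within the scatter). Compound 4 is estimated at 5 nM, between 1.5 nM and 20 nM.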

Compound 4, half-maximal effective concentration: 5.7 nM
Beside the measured number, compound 4's estimate is 1.1-fold (0.06 log units) below it; the range from low to high includes it.
By their numbers in this assay, from the lowest: compounds 4 and 3 (each within the scatter of the next); then compounds 2 and 1 (each within the scatter of the next).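

In this assay, cycloheptyl in place of neopentyl exchanges one saturated group for another and gives a 1.1-fold lower number from compound 3 to compound 4 (0.04 log units; within the scatter) at this place, so a ring of carbon only and an open chain cannot be told apart here. The large gap to the aryl compounds is not tied to neopentyl alone, as a 13-fold lower number from compound 2 to compound 4 (1.12 log units; beyond the scatter) and a 14-fold lower number from compound 1 to compound 4 (1.14 log units; beyond the scatter) both show. Nothing measured here explains these differences. As far as these compounds go, it remains open whether a smaller ring such as cyclopentyl would fit this pattern. The same holds for a saturated group carrying an amine or a carboxylic acid.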